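This account rests on a few compounds, and the source may have more. Where it says the series, first, only, none or still open, it means among the compounds named here.

Measured compounds:
Compound 1 `O=C1CS/C(=N\c2csc(-c3ccccc3)c2)N1` — in a functional assay on MCF7 cells (Homo sapiens) for cytotoxicity, read by MTT assay, with a stated time of 72 h (a higher number here means a weaker inhibitor, a lower number a stronger inhibitor), compound 1 gives > 50000 nM, a limit of the assay.
Compound 2 `O=C1CS/C(=N\c2csc(-c3ccc(Cl)cc3)c2)N1` — in this assay compound 2 gives > 50000 nM, likewise a limit.
Compound 3 `Cc1ccc(/C=C2\S/C(=N\c3csc(-c4ccc(Cl)cc4)c3)NC2=O)cc1` — in this assay compound 3 gives 900 nM.

Compound 3 thus carries the only number shown; the other two values are limits, as the limit of > 50000 nM in this assay, at which 2 of the 3 values shown sit, records, and for that reason the step that the two limits leave unreadable from compound 1 to compound 2 cannot be read. Compound 4 `CCCCCC/C=C1\S/C(=N\c2csc(-c3ccc(Cl)cc3)c2)NC1=O` differs from compound 3 by hexyl in place of 4-methylphenyl on a double-bonded chain carbon bound to a double-bonded ring carbon. For the measured compounds named here, no measured step touches this position, so the measured steps supply no size for it, in either direction. The step of a 5.6-fold higher number from compound 3 to compound 4 (0.74 log units; beyond the scatter) is therefore an estimate resting only on compound 3 and its value 900 nM. Compound 4 is expected to give 5000 nM, with a range from 900 nM to 50000 nM.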

Compound 4, half-maximal inhibitory concentration: > 50000 nM
Compound 4: a limit, no number; the forecaster's own chance of this, stated with the estimate: 30%; middle value at least 10-fold (1.00 log units) from the limit.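

In this assay, for the compounds shown here, hexyl in place of 4-methylphenyl on a double-bonded chain carbon bound to a double-bonded ring carbon gives an at least 55-fold higher number from compound 3 to compound 4 (1.74 log units; beyond the scatter) and so is the first readable step, a large one that goes towards weaker inhibition. On these data alone, compound 4 gives a limit and not a number, so the full size of the step stays unknown, and compound 3 alone retains a measured value: the limit of > 50000 nM in this assay, at which 3 of the 4 values shown sit.

The compounds shown leave open whether an unsubstituted phenyl, a pyridine ring or a shorter chain at this position would keep a value near that of compound 3.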